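A Single Step Guides the Acetyl Estimate

A few compounds are considered here, and "the series" means these few. Any claim that something is new, unique, unknown or untested is made for them only; others in the source may bear on it.

Compound 1 `Oc1cc2c(cc1CNc1ccccc1)OCCC2`: 1700 nM
Compound 2 `OCc1ccccc1NCc1cc2c(cc1O)CCCO2`: 21000 nM

Going by the values given here, in a functional assay for inhibition, with Homo sapiens as the target (on this read-out higher numbers stand for weaker inhibition and lower numbers for stronger inhibition), compound 1 gives 1700 nM, the lower of the two numbers so far. Compound 3 `CC(=O)c1ccc(NCc2cc3c(cc2O)CCCO3)cc1` carries acetyl in place of hydrogen on an aromatic carbon. Among the compounds with values here, only one measured step bears on this change, where hydroxymethyl replaces hydrogen on an aromatic carbon, and it is large: a 12-fold higher number from compound 1 to compound 2 (1.09 log units; beyond the scatter). One step is thin evidence, so a rise of smaller size is expected, estimated as a 2.4-fold higher number from compound 1 to compound 3 (0.37 log units; beyond the scatter). Compound 3 is expected at 4000 nM, with an estimated range of 1000 nM to 20000 nM.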

Compound 3, half-maximal inhibitory concentration: 4100 nM
Compound 3: middle estimate off by 1.0-fold (0.01 log units), on the low side; low and high end bracket the measured number.
By their numbers in this assay, from the lowest: compound 1; then compound 3; then compound 2.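

In this assay, acetyl on an aromatic carbon para to a large group gives a 2.4-fold higher number from compound 1 to compound 3 (0.38 log units; beyond the scatter), a modest step, so this position accepts a group of 3 heavy atoms with a limited loss of inhibition. Set beside a 12-fold higher number from compound 1 to compound 2 (1.09 log units; beyond the scatter), it shows that replacing hydrogen on this ring need not cost a large step, although both groups shown raise the number. Nothing available explains the size of this rise. From the compounds shown here alone, whether an amine or a carboxylic acid at this same position would lower the number instead remains open.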